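A few compounds are considered here, and "the series" means these few. Any claim that something is new, unique, unknown or untested is made for them only; others in the source may bear on it.

Compound 1 `c1ccc(-c2cc(-c3ccccn3)nc(-c3ccccn3)c2)cc1` is the shared core carrying a phenyl group together with two pyridin-2-yl groups. In a functional assay on RPTEC cells (Homo sapiens) for antiproliferative activity (a higher number here means a weaker inhibitor of growth, a lower number a stronger inhibitor of growth), compound 1 gives 0.027 ug/mL, the lowest of the three numbers measured. Compound 3 `c1ccc(-c2cc(-c3cccnc3)nc(-c3ccccn3)c2)cc1` gives 0.36 ug/mL, and compound 2 `c1ccc(-c2cc(-c3cccs3)cc(-c3ccncc3)n2)nc1` gives 0.65 ug/mL. Among the compounds with values here, the one single-site step known is a 13-fold higher number from compound 1 to compound 3 (1.12 log units; beyond the scatter), which shows that exchanging a pyridin-2-yl group on the core costs much. Compound 4 `c1ccc(-c2cc(-c3ccoc3)cc(-c3ccccn3)n2)nc1` is the compound not yet measured. It differs from compound 1 in that (furan-3-yl in place of phenyl on an aromatic carbon). Within the data shown here, no measured pair records a furan-3-yl for phenyl exchange, and compound 2 differs from compound 1 at two places at once, so its value gives no clean guide. Because the step of a 13-fold higher number from compound 1 to compound 3 (1.12 log units; beyond the scatter) ties the large loss to exchanging a pyridin-2-yl group, and both pyridin-2-yl groups stay in place in compound 4, the step of a 2.2-fold higher number from compound 1 to compound 4 (0.35 log units; beyond the scatter) is expected to be small, most likely a modest rise. Compound 4 is therefore estimated at 0.06 ug/mL in this assay, within a range of 0.015 ug/mL to 0.25 ug/mL.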

Compound 4, concentration for 50% growth inhibition: 0.0058 ug/mL
For compound 4 the middle estimate is 10-fold (1.01 log units) above the measured one; the measured number lies below the stated range.
By their numbers in this assay, from the lowest: compound 4; then compound 1; then compounds 3 and 2 (each within the scatter of the next).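

In this assay, within the data shown here, the exchange at the aromatic carbon opposite the ring nitrogen gives a 4.7-fold lower number from compound 1 to compound 4 (0.67 log units; beyond the scatter) and so moves the number down, while the only earlier single-site step, a 13-fold higher number from compound 1 to compound 3 (1.12 log units; beyond the scatter), exchanged a pyridin-2-yl group and moved it up. The phenyl group is therefore not required at this position, and a five-membered aromatic ring with one hetero atom serves better in this assay. The evidence at hand offers no explanation for this gain.

This single exchange cannot separate the effect of the ring oxygen from that of the smaller ring. As far as these compounds go, how an amine, a carboxylic acid or a short alkyl chain on this same carbon would compare with the furan-3-yl group also remains open.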